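The source may report more compounds than this note shows. Statements on the series, on what has been measured and on what is new or still open speak of the compounds shown alone.

Compound 1 `O=C(Oc1ccc(-c2ccccc2)cc1)c1cn(-c2ccccc2)nc1-c1cccnc1`; compound 2 `CCc1ccc(OC(=O)c2cn(-c3ccccc3)nc2-c2ccncc2)cc1`; compound 3 `CC(C)(C)c1ccc(OC(=O)c2cn(-c3ccccc3)nc2-c2ccncc2)cc1`.

Of the compounds shown here, three have been measured in a functional assay on MDA-MB-231 cells (Homo sapiens) for cytotoxicity, read by MTT assay, with a stated time of 48 h; on this read-out higher numbers stand for weaker inhibition and lower numbers for stronger inhibition. Compound 1 gives > 100000 nM, which is a limit of the assay and not a number. Compound 2 gives > 100000 nM, again a limit. Among the measured compounds shown here, compound 3 gives 34500 nM, the only actual number among the three, so compound 3 stands alone as the one compound with a measured value. For the measured compounds named here, the single step that can be read between measured compounds is an at least 2.8-fold lower number from compound 2 to compound 3 (0.46 log units; beyond the scatter); it is counted from a limit, so only its lower bound is known, and the limit of > 100000 nM in this assay, at which 2 of the 3 values shown sit, is the point where the two other compounds rest.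

Compound 4 `O=C(Oc1ccc(-c2ccccc2)cc1)c1cn(-c2ccccc2)nc1-c1ccncc1` is not yet measured. It differs from compound 3 by phenyl in place of tert-butyl on an aromatic carbon. Going by the values given here, the one measured step concerns tert-butyl against ethyl on the same aromatic carbon, so it bears on compound 4 only loosely: it shows that one larger group there moved the number down out of the limit, but nothing shows whether phenyl behaves like tert-butyl. With two of three values sitting at the limit, compound 4 is expected to remain weak in this assay, with a fair chance of returning to the limit. The expected step of a 2.3-fold higher number from compound 3 to compound 4 (0.37 log units; beyond the scatter) is therefore upward. Compound 4 is estimated at 80000 nM, between 20000 nM and 300000 nM.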

Compound 4, half-maximal inhibitory concentration: > 100000 nM
Compound 4 ended at the assay's limit; the forecaster's own chance of this, stated with the estimate: 55%; middle value at least 1.2-fold (0.09 log units) away from the limit.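

Putting phenyl in place of tert-butyl on this aromatic carbon, para to a large group, gives an at least 2.8-fold higher number from compound 3 to compound 4 (0.46 log units; beyond the scatter) in this assay. Thus the earlier gain with tert-butyl does not extend to every group with more heavy atoms than ethyl: among compound 2, compound 3 and compound 4, only the tert-butyl compound 3 gives an actual number, while ethyl and phenyl both leave their compounds at the limit. The steps from compound 2 and from compound 1 to compound 4 cannot be read, because both ends of each are limits: the limit of > 100000 nM in this assay, at which 3 of the 4 values shown sit.

Going by these compounds, how far compound 2 and compound 4 lie beyond that limit therefore stays unknown, and so does any difference between pyridin-3-yl and pyridin-4-yl with the phenyl group in place. Among the compounds shown here, it also remains open whether a carboxylic acid, an amine or a longer chain at this position would give a measurable number, or whether tert-butyl would remain the only group here to do so.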